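Difluoromethyl in Place of Hydrogen: Expected Cytotoxicity

This account rests on a few compounds, and the source may have more. Where it says the series, first, only, none or still open, it means among the compounds named here.

Three compounds sharing one core have been examined in an ADME assay on HEK293-A cells (Homo sapiens) for cytotoxicity, read by MTT assay, with a stated time of 48 h; a higher number here means a weaker inhibitor, a lower number a stronger inhibitor. Compound 1 `CC(=O)OC[C@H]1CN(c2ccc(-n3cc(-c4ccccn4)cn3)c(F)c2)C(=O)O1` gives > 400 ug/mL, which is a limit of the assay rather than a number. Compound 2 `O=C1O[C@@H](CSc2cccs2)CN1c1ccc(-n2cc(-c3ccccn3)cn2)c(F)c1` gives > 400 ug/mL, again a limit. Compound 3 `O=CNC[C@H]1CN(c2ccc(-n3cc(-c4ccccn4)cn3)c(F)c2)C(=O)O1` gives > 400 ug/mL, also a limit. The steps a step that the two limits leave unreadable from compound 1 to compound 2, a step that the two limits leave unreadable from compound 1 to compound 3 and a step that the two limits leave unreadable from compound 2 to compound 3 therefore cannot be sized, because every value sits at the limit of > 400 ug/mL in this assay, at which 3 of the 3 values shown sit.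

Compound 4 `O=C(NC[C@H]1CN(c2ccc(-n3cc(-c4ccccn4)cn3)c(F)c2)C(=O)O1)C(F)F` differs from compound 3 by difluoromethyl in place of hydrogen on a carbonyl carbon whose other neighbour is an amide-type nitrogen. Among the compounds with values here, none of the measured steps touches this position; they show only that three different side chains on this core all leave the read-out at a limit. In this assay compound 4 is accordingly expected to stay at a limit as well, with an expected step that the limit leaves unreadable from compound 3 to compound 4, meaning nothing beyond the scatter. Compound 4 is estimated at 450 ug/mL, expected between 250 ug/mL and 800 ug/mL.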

Compound 4, half-maximal inhibitory concentration: 167 ug/mL
Beside the measured number, compound 4's estimate is 2.7-fold (0.43 log units) above it; measured number below the stated range.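

In this assay, the carbonyl carbon whose other neighbour is an amide-type nitrogen proves to be a place where a change can be read: difluoromethyl in place of hydrogen gives an at least 2.3-fold lower number from compound 3 to compound 4 (0.37 log units; beyond the scatter). The ((difluoromethyl)carbonyl)amino side chain also stands apart from the other two side chains, with an at least 2.3-fold lower number from compound 2 to compound 4 (0.37 log units; beyond the scatter) and an at least 2.3-fold lower number from compound 1 to compound 4 (0.37 log units; beyond the scatter), so compound 4 alone gives a number rather than a limit. The steps among compound 1, compound 2 and compound 3 still cannot be read, and the three new steps give only minimum sizes: the limit of > 400 ug/mL in this assay, at which 3 of the 4 values shown sit.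

The compounds shown leave open how the read-out would respond to methyl, monofluoromethyl or trifluoromethyl on the same carbonyl carbon. They also leave open whether a longer chain carrying the difluoromethyl group would give a similar number.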